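Swapping a Hydroxy for a Methyl on a Biaryl Ester

A few compounds are considered here, and "the series" means these few. Any claim that something is new, unique, unknown or untested is made for them only; others in the source may bear on it.

Compound 1 `CCOC(=O)c1ccc(-c2ccc(OCC)cc2)[nH]1`: 44%
Compound 2 `CCOC(=O)c1cccc(-c2ccc(O)cc2)c1`: 77%

In an assay on COS-7 cells for inhibition of patatin-like phospholipase domain-containing protein 2 (Mus musculus), tested at 200 uM (a higher number here means more inhibition at the concentration tested (going by the name of the read-out), a lower number less inhibition), compound 2 gives the higher of the two measured numbers, and its gap to compound 1 lies beyond the usual scatter. Compound 3 `CCOC(=O)c1cccc(-c2ccc(C)cc2)c1` is not yet measured; it differs from compound 2 by a change on the six-membered aromatic ring of carbon only, para to a large group: methyl in place of hydroxy on an aromatic carbon. For the measured compounds named here, with no measured pair showing this change, the hydroxy of compound 2 is the only clue. A drop in this assay is expected, of size a number 27 percentage points lower from compound 2 to compound 3 (beyond the scatter). Compound 3 is therefore estimated at 50%, within 25% to 75%.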

Compound 3, a percentage reported as inhibition, at one concentration (the size of the read-out at that concentration, not a potency): 63%
Compound 3: the middle estimate sits 13 percentage points below what was measured; the measured number falls inside the stated range.
By their numbers in this assay, from the lowest: compound 1; then compound 3; then compound 2.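

In this assay, for the compounds shown here, this pair gives the first measured step at this position, a number 14 percentage points lower from compound 2 to compound 3 (beyond the scatter) on replacing hydroxy with methyl. The hydroxy therefore adds to the inhibition seen at this concentration, but compound 3 shows that much of the inhibition remains without it. Nothing available explains the difference between the two groups.

As far as these compounds go, what an amine, a methoxy group or a plain hydrogen would give on this aromatic carbon stays open. So does whether the same swap would have a similar effect on a different core.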